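The source may report more compounds than this note shows. Statements on the series, on what has been measured and on what is new or still open speak of the compounds shown alone.

Of the compounds shown here, three sharing one core have been measured in a functional assay on PC-3 cells (Homo sapiens) for inhibition, read by sulforhodamine B assay, with a stated time of 48 h, tested at 10 uM; a higher number here means more inhibition at the concentration tested (going by the name of the read-out), a lower number less inhibition. Compound 1 `c1ccc(-c2cn3ccnc3c(-c3ccc4ncn(C5CCCCC5)c4c3)n2)cc1` carries an unsubstituted phenyl group and gives 92%. Compound 2 `Fc1ccc(-c2cn3ccnc3c(-c3ccc4ncn(C5CCCCC5)c4c3)n2)cc1` gives 53.6%, and compound 3 `CC(=O)c1ccc(-c2cn3ccnc3c(-c3ccc4ncn(C5CCCCC5)c4c3)n2)cc1` gives 17.9%, the lowest of the three numbers. The steps run one way: a number 38.4 percentage points lower from compound 1 to compound 2 (beyond the scatter), a number 74.1 percentage points lower from compound 1 to compound 3 (beyond the scatter), and a number 35.7 percentage points lower from compound 2 to compound 3 (beyond the scatter). Each addition to the phenyl ring of compound 1 has lowered inhibition, the acetyl group most of all.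

Compound 4 `c1csc(-c2cn3ccnc3c(-c3ccc4ncn(C5CCCCC5)c4c3)n2)c1` is not yet measured. It differs from compound 3 in one place: thiophen-2-yl in place of 4-acetylphenyl on an aromatic carbon. For the measured compounds named here, no measured step exchanges the phenyl ring itself, so the three steps bear on this only in showing that compound 3, which carries the acetyl group, gives the lowest number of the three in this assay. From the compounds shown here alone, removing it, and putting an unsubstituted ring in its place, is expected to recover much of the inhibition of compound 1, though the thiophene is untested. Compound 4 is therefore expected to rise by a number 52.1 percentage points higher from compound 3 to compound 4 (beyond the scatter), to about 70%, within 35% to 95%.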

Compound 4, a percentage reported as inhibition, at one concentration (the size of the read-out at that concentration, not a potency): 49.1%
Compound 4: middle estimate off by 20.9 percentage points, on the high side; measured number inside the range.
By their numbers in this assay, from the lowest: compound 3; then compounds 4 and 2 (each within the scatter of the next); then compound 1.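

This position does not depend only on having an unsubstituted ring: in this assay, thiophen-2-yl in place of phenyl gives a number 42.9 percentage points lower from compound 1 to compound 4 (beyond the scatter), so the phenyl ring of compound 1 is not freely exchanged for this five-membered ring. Thiophen-2-yl in place of 4-acetylphenyl gives a number 31.2 percentage points higher from compound 3 to compound 4 (beyond the scatter), while in place of 4-fluorophenyl it gives a number 4.5 percentage points lower from compound 2 to compound 4 (within the scatter), which leaves compound 4 and compound 2 level and both short of compound 1. Nothing available explains these differences.

The compounds shown leave open whether an amine or a carboxylic acid on the phenyl ring of compound 1 would also lower the number. They also leave open whether any group at this position can match compound 1.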